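Amide variation on the shared core: compound 3 to compound 4

A few compounds are considered here, and "the series" means these few. Any claim that something is new, unique, unknown or untested is made for them only; others in the source may bear on it.

The series shares one core; compound 3 is `CCCSc1nc(Cl)c2c(n1)N(Cc1ccccc1)C(C(=O)OCC)N2`, compound 1 is `CCCSc1nc(Cl)c2c(n1)N(Cc1ccccc1)C(C(=O)N1CCN(C)CC1)N2` and compound 2 is `CCCSc1nc(Cl)c2c(n1)N(Cc1ccccc1)C(C(=O)NCC(C)C)N2`. In a functional assay on PC-3 cells (Homo sapiens) for antiproliferative activity, read by MTT assay, with a stated time of 72 h (on this read-out lower numbers stand for stronger inhibition and higher numbers for weaker inhibition), compound 3 gives 62500 nM, the highest of the two numbers shown, and compound 1 gives 29800 nM, the nearest, reached by a 2.1-fold higher number from compound 1 to compound 3 (0.32 log units; beyond the scatter). For compound 2 the read-out is a limit, > 64000 nM, and not a number (the limit of > 64000 nM in this assay, at which 1 of the 3 values shown sits). The step of an at least 1.0-fold lower number from compound 2 to compound 3 (0.01 log units; that floor lies within the scatter) is therefore only a floor, and that floor lies within the scatter.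

Compound 4 is `CCCSc1nc(Cl)c2c(n1)N(Cc1ccccc1)C(C(=O)Nc1ccccc1)N2`. It differs from compound 3 by anilino in place of ethoxy on a carbonyl carbon. Within the data shown here, two measured steps touch the same carbonyl carbon: a 2.1-fold higher number from compound 1 to compound 3 (0.32 log units; beyond the scatter) was beyond the scatter, whereas an at least 1.0-fold lower number from compound 2 to compound 3 (0.01 log units; that floor lies within the scatter) gave only a floor within it. Among the measured compounds shown here, no measured step compares anilino with any other group, and none places an aromatic ring at this position, so the nearest precedent is the exchange of ethoxy for isobutylamino, which showed no movement that can be counted. For compound 4 a step of a 1.0-fold lower number from compound 3 to compound 4 (0.02 log units; within the scatter) is expected, that is, nothing beyond the scatter. Compound 4 is accordingly estimated at 60000 nM, between 25000 nM and 130000 nM, with a fair chance that only a limit is returned.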

Compound 4, half-maximal inhibitory concentration: > 64000 nM
Compound 4 was reported as a limit (the forecaster's own chance of this, stated with the estimate: 40%); at least 1.0-fold (0.02 log units) between middle value and limit.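

Compound 4 returns only a limit, not a number, in this assay, and compound 2 is the other compound held at that limit: the limit of > 64000 nM in this assay, at which 2 of the 4 values shown sit.

This adds an aromatic ring on the carbonyl carbon to the picture, yet the exchange of ethoxy for anilino gives an at least 1.0-fold higher number from compound 3 to compound 4 (0.01 log units; that floor lies within the scatter), a floor that says nothing about a real change at this position. Against the one amide that returned a number, the result is clearer, with an at least 2.1-fold higher number from compound 1 to compound 4 (0.33 log units; beyond the scatter), so compound 1 is now beyond the scatter from all three other compounds, whether the group on the carbonyl carbon is ethoxy, isobutylamino or anilino, and the step between the two limits, phenyl against isobutyl on the amide-type nitrogen, cannot be read.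

On these data alone, it remains open whether the lower number of compound 1 belongs to the 4-methylpiperazin-1-yl group in particular or to ring amides more widely, which a morpholin-4-yl or piperidin-1-yl group on the same carbonyl carbon would help to separate. Also open, as far as these compounds go, is whether a benzylamino group, a substituted anilino group or a free carboxylic acid at this carbon would give a readable number at all.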